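Trimming the Isopropyl Group of Compound 3

This account rests on a few compounds, and the source may have more. Where it says the series, first, only, none or still open, it means among the compounds named here.

Going by the values given here, in a functional assay on HCT-116 cells (Homo sapiens) for antiproliferative activity, read by MTT assay, with a stated time of 48 h (on this read-out lower numbers stand for stronger inhibition and higher numbers for weaker inhibition), compound 3 (`CC(C)c1ccc(C(=O)/C=C/c2ccc(/C=C/C(=O)NO)o2)cc1`) gives 490 nM as the lowest of the three numbers so far. Compound 1 (`O=C(/C=C/c1ccc(/C=C/C(=O)c2cccc(Cl)c2)o1)NO`) stands at 1510 nM and compound 2 (`O=C(/C=C/c1ccc(/C=C/C(=O)c2ccccc2)o1)NO`) at 2890 nM in this series. Compound 4 (`Cc1ccc(C(=O)/C=C/c2ccc(/C=C/C(=O)NO)o2)cc1`) has yet to be measured and differs from compound 3 by methyl in place of isopropyl on an aromatic carbon. The most relevant evidence is the change of hydrogen to isopropyl at that place, which gave a 5.9-fold lower number from compound 2 to compound 3 (0.77 log units; beyond the scatter) beyond the scatter. The change of chloro to hydrogen, seen as a 1.9-fold higher number from compound 1 to compound 2 (0.28 log units; within the scatter) within the scatter, offers little guidance. Methyl stands structurally between hydrogen and isopropyl, so a partial return along a 5.9-fold lower number from compound 2 to compound 3 (0.77 log units; beyond the scatter) is expected in this assay toward a higher number. The expected step is a 1.9-fold higher number from compound 3 to compound 4 (0.29 log units; within the scatter) and its size is modest. For compound 4 the estimated value is 950 nM with 450 nM to 2000 nM as its expected range.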

Compound 4, half-maximal inhibitory concentration: 540 nM
Estimate against measurement, compound 4: 1.8-fold (0.25 log units) above, within the range that was stated.
By their numbers in this assay, from the lowest: compounds 3 and 4 (each within the scatter of the next); then compounds 1 and 2 (each within the scatter of the next).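

In this assay, shortening isopropyl to methyl at this position, para to a large group, leaves the number essentially unchanged, with a 1.1-fold higher number from compound 3 to compound 4 (0.04 log units; within the scatter), so compound 3 and compound 4 cannot be put in order. The methyl group alone is therefore enough to give a clear step over hydrogen, seen as a 5.4-fold lower number from compound 2 to compound 4 (0.73 log units; beyond the scatter), and the 4-methylphenyl group also stands clear of the 3-chlorophenyl group, with a 2.8-fold lower number from compound 1 to compound 4 (0.45 log units; beyond the scatter). Nothing available here bears on why isopropyl and methyl read alike in this assay.

From the compounds shown here alone, whether this tolerance extends to a methoxy group, an amine or a carboxylic acid at the same place remains open. So does whether a longer chain or a tert-butyl group would keep the number at this level.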